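A linker-matched hybrid of two bivalent histamine agonists

This account rests on a few compounds, and the source may have more. Where it says the series, first, only, none or still open, it means among the compounds named here.

Three bivalent compounds have been tested in an in vitro functional assay on Sf9 cells for agonist activity at histamine H2 receptor (Homo sapiens); on this read-out higher numbers stand for an effect only at larger amounts of compound and lower numbers for an effect already at smaller amounts. Compound 3 `N/C(=N\C(=O)CCCCCCCCC(=O)/N=C(\N)NCCCc1c[nH]cn1)NCCCc1c[nH]cn1` gives 6.17 nM, the lowest number of the three. Its nearest neighbour is compound 1 `Cc1nc(N)sc1CCCN/C(N)=N/C(=O)CCCCCCCCCCC(=O)/N=C(\N)NCCCc1sc(N)nc1C`, which gives 16.6 nM, a gap beyond the scatter; the furthest is compound 2 `N/C(=N\C(=O)CCCCC(=O)/N=C(\N)NCCCc1c[nH]cn1)NCCCc1c[nH]cn1`, which gives 214 nM, a much larger gap. Compound 2 and compound 3 share their end groups and differ only in the length of the connecting chain, while compound 1 carries a different end group at both ends and a longer chain than compound 3. Going by the values given here, no single-point step between measured compounds is available.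

Compound 4 `Cc1nc(N)sc1CCCN/C(N)=N/C(=O)CCCCCCCCC(=O)/N=C(\N)NCCCc1c[nH]cn1` keeps the chain of compound 3 and alters one end: 2-amino-4-methyl-1,3-thiazol-5-yl in place of 1H-imidazol-4-yl on a saturated chain carbon, three bonds along the chain from an amine nitrogen. Because compound 1, which carries the entering group at both of its ends, gives 16.6 nM, and compound 3 gives 6.17 nM, the hybrid is expected to fall between these two, with a small step upward from compound 3 that may not exceed the scatter. The expected step is a 1.6-fold higher number from compound 3 to compound 4 (0.21 log units; within the scatter). Compound 4 is therefore estimated at 10 nM, with a range from 4 nM to 25 nM.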

Compound 4, half-maximal effective concentration: 7.59 nM
Beside the measured number, compound 4's estimate is 1.3-fold (0.12 log units) above it, within the range that was stated.
By their numbers in this assay, from the lowest: compounds 3 and 4 (each within the scatter of the next); then compound 1; then compound 2.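

Read in this assay, the exchange of 1H-imidazol-4-yl for 2-amino-4-methyl-1,3-thiazol-5-yl gives a 1.2-fold higher number from compound 3 to compound 4 (0.09 log units; within the scatter) on a saturated chain carbon, three bonds along the chain from an amine nitrogen, which is the first single-point step at this position. It shows that one end of the bivalent compound can carry either group on this chain without a difference that this read-out can separate, even though the entering group has 7 heavy atoms against 5, includes a sulfur and counts 3 hydrogen-bond acceptors against 1. No measurement at hand offers an explanation for this result.

The compounds shown leave open whether the same exchange would read alike on a shorter chain, such as that of compound 2, which gives 214 nM in this assay, or on a longer chain. They also leave open whether an ethyl group in place of the methyl of the 2-amino-4-methyl-1,3-thiazol-5-yl end would keep the number within the scatter of compound 3.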